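The source may report more compounds than this note shows. Statements on the series, on what has been measured and on what is new or still open speak of the compounds shown alone.

Measured so far:
compound 1, `O=C(Nc1cnn(-c2ccccc2)c1)c1cccc(NS(=O)(=O)c2ccccc2)c1`: 4320 nM
compound 2, `Cc1ccc(-n2cc(NC(=O)c3cccc(NS(=O)(=O)c4ccccc4)c3)cn2)cc1`: 1690 nM
compound 3, `O=C(Nc1cnn(-c2ccccc2)c1)c1ccc(NS(=O)(=O)c2ccccc2)cc1`: 17100 nM

The three compounds were tested in a functional assay on MCF7 cells (Homo sapiens) for inhibition, read by MTT assay, with a stated time of 48 h; a lower number here means a stronger inhibitor, a higher number a weaker inhibitor. Compound 1 gives 4320 nM, compound 2 gives 1690 nM, and compound 3 gives 17100 nM.

Compound 1 and compound 2 differ in one place:

methyl in place of hydrogen on an aromatic carbon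

That change made a 2.6-fold lower number from compound 1 to compound 2 (0.41 log units; beyond the scatter).

Compound 3 shares its atoms with compound 1 but joins them differently; the difference between the two cores is not broken down here. Its number is the highest of the three, and its gap to compound 1 as well as to compound 2 is beyond the usual scatter.

Compound 4, `Cc1ccc(-n2cc(NC(=O)c3ccc(NS(=O)(=O)c4ccccc4)cc3)cn2)cc1`, has not yet been measured. It differs from compound 3 in one place:

methyl in place of hydrogen on an aromatic carbon

This is the same change that turns compound 1 into compound 2, made on the core of compound 3 rather than on that of compound 1. The step from compound 3 to compound 4 is expected to be about the size of the earlier one, a 2.6-fold lower number from compound 3 to compound 4 (0.41 log units; beyond the scatter), because the change is the same and it made a 2.6-fold lower number from compound 1 to compound 2 (0.41 log units; beyond the scatter); the only reservation is that the cores differ, and nothing here shows how the change behaves on the core of compound 3. Compound 4 is therefore expected to give about 6600 nM in this assay, most likely between 3000 nM and 15000 nM.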

Compound 4, half-maximal inhibitory concentration: 10900 nM
Estimate against measurement, compound 4: 1.7-fold (0.22 log units) below; measured number inside the range.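

Placed on the second core, the change from phenyl to 4-methylphenyl gives a 1.6-fold lower number from compound 3 to compound 4 (0.20 log units; within the scatter) in this assay, so this step alone cannot be told apart from the ordinary spread of repeated measurements. Two cores are also too few to show that the methyl would act the same way on any further core, and the result does not establish a real gain on the second core. Even so, the two steps do not differ by more than repeated measurements allow, so nothing here argues against carrying the change from one core to the other: the same change on two cores in this assay, a 2.6-fold lower number (0.41 log units; beyond the scatter) from compound 1 to compound 2 and a 1.6-fold lower number (0.20 log units; within the scatter) from compound 3 to compound 4, 1.6-fold (0.21 log units) apart, within the scatter of two such steps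

The compounds shown compare only hydrogen and methyl at this place on the ring, so they leave open what an ethyl group, a chlorine atom or a methoxy group would do there, and whether any of these would give a step that clearly exceeds the scatter on both cores. They also leave open how the series would respond to an amine or a carboxylic acid on the phenyl ring attached to the sulfonyl group, since that ring is the same in all four compounds.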